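Replacing the triazole side chain of compound 2 with a piperidinylethyl group

A few compounds are considered here, and "the series" means these few. Any claim that something is new, unique, unknown or untested is made for them only; others in the source may bear on it.

Compound 1 `O=C1c2c[n+]([O-])c3ccccc3c2C(=O)c2c1c1ccccc1n2Cc1cn([C@@H]2C[C@H](O)[C@@H](CO)O2)nn1` gives 150 nM in a functional assay on SH-SY5Y cells (Homo sapiens) for cytotoxicity, read by MTT assay, with a stated time of 72 h; on this read-out higher numbers stand for weaker inhibition and lower numbers for stronger inhibition. Compound 2 `O=C1c2c[n+]([O-])c3ccccc3c2C(=O)c2c1c1ccccc1n2Cc1cn(C[C@H](O)CO)nn1` reaches only the limit of the same assay, > 1000 nM, so no number is known for it (the limit of > 1000 nM in this assay, at which 1 of the 3 values shown sits). Compound 3 `CC1(C)OC[C@H](Cn2cc(Cn3c4c(c5ccccc53)C(=O)c3c[n+]([O-])c5ccccc5c3C4=O)nn2)O1` gives 820 nM. The step of an at least 6.6-fold higher number from compound 1 to compound 2 (0.82 log units; beyond the scatter) and the step of a 5.5-fold higher number from compound 1 to compound 3 (0.74 log units; beyond the scatter) both lie beyond the scatter, while the step of an at least 1.2-fold lower number from compound 2 to compound 3 (0.08 log units; that floor lies within the scatter) does not.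

Compound 4 `O=C1c2c[n+]([O-])c3ccccc3c2C(=O)c2c1c1ccccc1n2CCN1CCCCC1` differs from compound 2 by (piperidin-1-yl)methyl in place of 1-(2,3-dihydroxypropyl)-1H-1,2,3-triazol-4-yl on a saturated chain carbon bound to an aromatic nitrogen. Going by the values given here, none of the measured steps touches this kind of change: all three compounds carry the triazole, and they differ only in what sits on it. The move to compound 4 removes the triazole and its diol altogether, so the measured steps give no direction for it. Compound 4 is therefore expected near the weaker compounds, with wide uncertainty, at an estimated 600 nM (range 150 nM to 3000 nM), which would mean an expected step of an at least 1.6-fold lower number from compound 2 to compound 4 (0.22 log units; that floor lies within the scatter).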

Compound 4, half-maximal inhibitory concentration: 1860 nM
Beside the measured number, compound 4's estimate is 3.1-fold (0.49 log units) below it, within the range that was stated.
By their numbers in this assay, from the lowest: compound 1; then compound 3; then compound 4.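

No new step can be read from compound 2 to compound 4, because the value of compound 2 is only a limit: the limit of > 1000 nM in this assay, at which 1 of the 4 values shown sits.

The compounds shown leave open how (piperidin-1-yl)methyl compares with 1-(2,3-dihydroxypropyl)-1H-1,2,3-triazol-4-yl at this place in size and direction.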